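Shortening the Ketone Side Chain to an Acetyl Group

The source may hold more compounds than are shown below. What is called first, only, known or untested is meant among the compounds shown, and "the series" means these compounds.

The measured compounds, all tested in an assay on HEK293 cells for positive allosteric modulation of metabotropic glutamate receptor 2 (Rattus norvegicus), read by thallium flux, with a stated time of 2.5 min; a lower number here means a smaller maximal response, a higher number a larger maximal response:

Compound 1 `Cc1c(OCCCCOc2ccc(C(=O)CC(C)(C)C)c(O)c2C)cccc1C(=O)O` gives 95.8% in this assay.
Compound 2 `Cc1c(OCCCCOc2ccc(F)c(C(=O)O)c2)ccc(C(=O)CC2CCCC2)c1O` gives 81% in this assay.
Compound 3 `CCCC(=O)c1ccc(OCCCCOc2ccc(F)c(C(=O)O)c2)c(C)c1O` gives 87.5% in this assay.

Compound 3 sits among the three numbers with compound 2 as its nearest neighbour and compound 1 as its furthest, and both gaps lie within the scatter of repeated measurements, so the three compounds cannot be told apart on these data.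

Compound 4 `CC(=O)c1ccc(OCCCCOc2ccc(F)c(C(=O)O)c2)c(C)c1O` has not yet been measured in this assay. It differs from compound 3 as follows: hydrogen in place of ethyl on a saturated chain carbon bound to a carbonyl carbon. Going by the values given here, only one measured step bears on this change, and it sits at the same place: a number 6.5 percentage points higher from compound 2 to compound 3 (within the scatter). That step, which swaps one saturated group for another on the saturated chain carbon bound to the carbonyl carbon, stayed within the scatter. The move from compound 3 to compound 4 removes the ethyl group from that same position, a smaller change in the same direction of trimming the chain.

He therefore expects no step beyond the scatter, a number 1.5 percentage points lower from compound 3 to compound 4 (within the scatter), and estimates that compound 4 will give 86% in this assay, within a range from 74% to 98%.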

Compound 4, largest response reached (reported as percent of maximum), in percent of the reference or control that the assay uses: 75.5%
Compound 4: the middle estimate sits 10.5 percentage points above what was measured, and the stated range covers the measured number.
By their numbers in this assay, from the lowest: compounds 4, 2, 3 and 1 (each within the scatter of the next, the first and the last beyond it).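

Going by these compounds alone, removing the ethyl group, so that propylcarbonyl becomes acetyl, gives in this assay a step beyond the scatter, a number 12 percentage points lower from compound 3 to compound 4 (beyond the scatter), whereas the only earlier change at this position stayed within it, a number 6.5 percentage points higher from compound 2 to compound 3 (within the scatter). This position can therefore shift the maximal response, though modestly, and the shift does not simply follow the size of the group removed: replacing the larger cyclopentyl with hydrogen gives a number 5.5 percentage points lower from compound 2 to compound 4 (within the scatter), which remains within the scatter. Nothing shown here explains why the step from ethyl to hydrogen stands out.

The compounds shown carry only hydrogen or saturated carbon groups on the saturated chain carbon bound to the carbonyl carbon, so it remains open how an amine or a phenyl ring at that place would compare with the ethyl of compound 3. Going by these compounds, it also remains open whether the same change to acetyl would lower the response on the core of compound 1, which differs from the other compounds in more than one place.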